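Hydrazone series: cytotoxicity and an aromatic hydroxy step

The compounds below may be only part of what the source reports. "The series", "measured", "known", "first", "only" and "open" are said of these compounds alone.

Measured so far:
compound 1 `O=C(N/N=C/c1ccccc1)c1cccnc1`: > 100 ug/mL
compound 2 `O=C(N/N=C/c1ccc(Cl)cc1)c1cccnc1`: > 100 ug/mL
compound 3 `O=C(N/N=C/c1ccc(F)cc1)c1cccnc1`: > 100 ug/mL

In an ADME assay on HEL cells (Homo sapiens) for cytotoxicity, read by microscopy (on this read-out lower numbers stand for higher toxicity in this test and higher numbers for lower toxicity in this test), compound 1 reaches only a limit of the assay, > 100 ug/mL, and no number. Compound 2 likewise stops at the limit > 100 ug/mL. Compound 3 also stops at the limit > 100 ug/mL. The steps a step that the two limits leave unreadable from compound 1 to compound 2, a step that the two limits leave unreadable from compound 1 to compound 3 and a step that the two limits leave unreadable from compound 2 to compound 3 therefore cannot be sized; what is known is the limit of > 100 ug/mL in this assay, at which 3 of the 3 values shown sit.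

Compound 4 `O=C(N/N=C/c1ccccc1O)c1cccnc1` differs from compound 1 by hydroxy in place of hydrogen on an aromatic carbon. Among the compounds with values here, none of the measured steps concerns a hydroxy, and none of them has a readable size, so no step beyond the scatter in this assay is expected in either direction from compound 1 to compound 4; chloro and fluoro on the same ring also gave only the limit. Compound 4 is therefore expected at about 100 ug/mL, within 50 ug/mL to 200 ug/mL, most probably again reported only as a limit. The step this estimate means, a number no higher from compound 1 to compound 4 (the limit leaves the size open), is expected to stay within the scatter.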

Compound 4, minimum cytotoxic concentration: >= 4 ug/mL
Compound 4 ended at the assay's limit (the forecaster's own chance of this, stated with the estimate: 80%); the middle value lies beyond the limit too.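

In this assay, compound 1 and compound 4 both stand at limits of the assay and not at numbers, and the step between them cannot be read. The compounds shown leave open whether hydroxy in place of hydrogen on an aromatic carbon changes the read-out in this assay at all, and in which direction.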